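Cyano for methyl on a shared core

This account rests on a few compounds, and the source may have more. Where it says the series, first, only, none or still open, it means among the compounds named here.

In an ADME assay on Raji cells (Homo sapiens) for cytotoxicity, read by CellTiter-Glo, with a stated time of 72 h (on this read-out higher numbers stand for an effect only at larger amounts of compound and lower numbers for an effect already at smaller amounts), compound 1 `CC1=C2CC(C)(C)/C=C/C(=O)/C(C)=C\C3=C[C@H](C)C[C@]3(O2)[C@@]1(O)C(F)(F)F` reads 26000 nM and compound 2 `CC1=C2CC(C)(C)/C=C/C(=O)/C(C)=C\C3=C[C@H](C)C[C@]3(O2)[C@]1(C)O` reads 26000 nM as well, so compound 2 stands level with compound 1. Compound 3 `CC1=C2CC(C)(C)/C=C/C(=O)/C(C)=C\C3=C[C@H](C)C[C@]3(O2)[C@@]1(O)C#N` carries cyano in place of methyl on a saturated ring carbon of compound 2 (cyano in place of methyl on a saturated ring carbon). Among the compounds with values here, the one measured step on that carbon is no change at the digits printed from compound 1 to compound 2 (within the scatter) and it puts methyl in place of trifluoromethyl, but no compound with cyano has been measured. So the expected result is no change at the digits printed from compound 2 to compound 3 (within the scatter) in this assay with no shift beyond the scatter in either direction. The estimated value for compound 3 is 26000 nM (expected range 11000 nM to 50000 nM).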

Compound 3, half-maximal effective concentration: 21200 nM
Estimate against measurement, compound 3: 1.2-fold (0.09 log units) above; low and high end bracket the measured number.
By their numbers in this assay, from the lowest: compounds 3, 1 and 2 (each within the scatter of the next).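

In this assay the change from methyl to cyano gives a 1.2-fold lower number from compound 2 to compound 3 (0.09 log units; within the scatter) and the change from trifluoromethyl to cyano gives a 1.2-fold lower number from compound 1 to compound 3 (0.09 log units; within the scatter) as well. This saturated ring carbon has now carried three different groups with no reading beyond the scatter, even though cyano brings a triple bond and a hydrogen-bond acceptor that methyl lacks. Nothing available explains why these readings sit so close together. Going by these compounds, whether an amine, a carboxylic acid or a longer chain on this carbon would read the same remains open.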